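The source may hold more compounds than are shown below. What is called first, only, known or untested is meant among the compounds shown, and "the series" means these compounds.

- Compound 1 `Nc1ncnn2c([C@@H]3O[C@H](CO)[C@@H](O)[C@H]3O)cc(C#CC3CC3)c12`: 40 nM
- Compound 2 `Nc1ncnn2c([C@@H]3O[C@H](CO)[C@@H](O)[C@H]3O)cc(C#Cc3cccs3)c12`: > 100000 nM
- Compound 3 `Nc1ncnn2c([C@@H]3O[C@H](CO)[C@@H](O)[C@H]3O)cc(-c3ccc(F)cc3)c12`: 68300 nM

In a functional assay on HL-60 cells (Homo sapiens) for antiproliferative activity, with a stated time of 72 h (on this read-out higher numbers stand for weaker inhibition and lower numbers for stronger inhibition), compound 2 stands at > 100000 nM, which is a limit of the assay and not a number. Compound 4 `COc1ccc(-c2cc([C@@H]3O[C@H](CO)[C@@H](O)[C@H]3O)n3ncnc(N)c23)cc1` carries 4-methoxyphenyl in place of 2-(thiophen-2-yl)ethynyl on an aromatic carbon. Among the compounds with values here, two large steps, an at least 2500-fold higher number from compound 1 to compound 2 (3.39 log units; beyond the scatter) and a 1700-fold higher number from compound 1 to compound 3 (3.23 log units; beyond the scatter), lead away from the one low value. The closest case for the new change is the swap to 4-fluorophenyl, an at least 1.4-fold lower number from compound 2 to compound 3 (0.16 log units; that floor lies within the scatter). On that basis, the expected change is none beyond the scatter: an at least 1.6-fold lower number from compound 2 to compound 4 (0.22 log units; that floor lies within the scatter). For compound 4 the estimate is 60000 nM, with an expected range from 20000 nM to 100000 nM.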

Compound 4, half-maximal inhibitory concentration: > 100000 nM
Compound 4: no number, only a limit (the forecaster's own chance of this, stated with the estimate: 35%); middle value at least 1.6-fold (0.22 log units) from the limit.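

The result for compound 4 is a limit of the assay and not a number, so the step from compound 2, itself a limit, cannot be read. Methoxy in place of fluoro gives an at least 1.4-fold higher number from compound 3 to compound 4 (0.16 log units; that floor lies within the scatter), a floor too small to show a real change. The gap to 2-cyclopropylethynyl stays large with 4-methoxyphenyl at this position, an at least 2500-fold higher number from compound 1 to compound 4 (3.39 log units; beyond the scatter), so among these four compounds only compound 1 gives a low value.

Still open, as far as these compounds go, is whether that low value needs the triple bond, the cyclopropyl ring or both. A plain cyclopropyl on this carbon, or a straight butyl chain on the triple bond, would separate the two.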